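The compounds below may be only part of what the source reports. "The series", "measured", "known", "first", "only" and "open" are said of these compounds alone.

The measured compounds are:

compound 1, `CC(C)(C)OC(=O)NCCCCCN1C(Nc2ccc(-c3ccccc3)cc2)=Nc2ccccc2C1CC(=O)NCc1ccccc1`, which in an assay on HEK293 cells for inhibition of Voltage-dependent N-type calcium channel subunit alpha-1B (Homo sapiens), tested at 10 uM (on this read-out higher numbers stand for more inhibition at the one concentration tested (going by the name of the read-out) and lower numbers for less inhibition), gives 30.1%;
compound 2, `COC(=O)CC1c2ccccc2N=C(NCCCCCNC(=O)OC(C)(C)C)N1c1ccc(-c2ccccc2)cc1`, which in this assay gives 98.6%;
compound 3, `COC(=O)CC1c2ccccc2N=C(Nc2ccc(-c3ccccc3)cc2)N1CCCCCNC(=O)OC(C)(C)C`, which in this assay gives 94.9%.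

Compound 2 and compound 3 are built from the same atoms joined differently; the difference between their two cores is not broken down here. Their values in this assay lie within the usual scatter of each other, so nothing separates them. One structural change is seen in measured form: from compound 3 to compound 1 the change is benzylamino in place of methoxy on a carbonyl carbon, and it brought a number 64.8 percentage points lower from compound 3 to compound 1 (beyond the scatter).

Compound 4, `CC(C)(C)OC(=O)NCCCCCNC1=Nc2ccccc2C(CC(=O)NCc2ccccc2)N1c1ccc(-c2ccccc2)cc1`, has not yet been measured. It differs from compound 2 by benzylamino in place of methoxy on a carbonyl carbon, the same change at the same kind of place, here made on the core of compound 2 rather than the core of compound 3. Compound 4 is therefore expected to show a step of about a number 63.6 percentage points lower from compound 2 to compound 4 (beyond the scatter) in this assay because the same change gave a number 64.8 percentage points lower from compound 3 to compound 1 (beyond the scatter). Compound 4 is accordingly estimated at 35% in this assay. Among the measured compounds shown here, for compound 4 the expected range runs from 10% to 70%, the width reflecting that only one example of this change is known and that the two cores are not identical.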

Compound 4, a percentage reported as inhibition, at one concentration (the size of the read-out at that concentration, not a potency): 16.6%
For compound 4 the middle estimate is 18.4 percentage points above the measured one; low and high end bracket the measured number.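

On the core of compound 2, benzylamino in place of methoxy on a carbonyl carbon brought a number 82 percentage points lower from compound 2 to compound 4 (beyond the scatter) in this assay, so the fall seen on the core of compound 3 appears here as well. The direction of the change carries over from one core to the other, but its size does not: the same change on two cores in this assay, a number 64.8 percentage points lower (beyond the scatter) from compound 3 to compound 1 and a number 82 percentage points lower (beyond the scatter) from compound 2 to compound 4, 17.2 percentage points apart, beyond the scatter of two such steps. These two pairs do not explain why the size differs, and they cannot show how the same change would behave on any further core.

With only methoxy and benzylamino shown on this carbonyl carbon, it remains open whether a benzyloxy group, which keeps the aromatic ring but not the nitrogen, or a methylamino group, which keeps the nitrogen but not the ring, would give a high or a low reading. Also open, going by these compounds, is how this change would behave with a free amine in place of the carbamate that all four compounds carry.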